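The compounds below may be only part of what the source reports. "The series", "measured", "known", "first", "only" and "open" are said of these compounds alone.

Measured compounds:
Compound 1 `Nc1cc(N)c2nc(-c3ccccc3)c(NCc3ccc(F)cc3)nc2c1` in a functional assay on NCI-H522 cells (Homo sapiens) for inhibition, read by sulforhodamine B assay, with a stated time of 48 h (on this read-out lower numbers stand for higher toxicity in this test and higher numbers for lower toxicity in this test), gives < 100000 nM, which is a limit of the test and not a number.
Compound 2 `Nc1cc(N)c2nc(-c3ccccc3)c(Oc3ccc(F)cc3)nc2c1` in this assay gives < 100000 nM, again a limit of the test and not a number.

Compound 2 therefore cannot be placed on a scale: its value is only known as a limit, and the same holds for the other value shown. Among the measured compounds shown here, the single measured step, a step that the two limits leave unreadable from compound 1 to compound 2, is unreadable in size and direction, since both of its ends rest on limits, as the limit of < 100000 nM in this assay, at which 2 of the 2 values shown sit, records.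

Compound 3 `Nc1cc(N)c2nc(-c3ccccc3)c(Sc3ccc(F)cc3)nc2c1` differs from compound 2 in one place: (4-fluorophenyl)sulfanyl in place of 4-fluorophenoxy on an aromatic carbon. For the measured compounds named here, the only measured step does not bear on this change in any readable way, so there is nothing in the data that would suggest a step in this assay beyond the scatter, in either direction. The step is accordingly expected to be a step that the limit leaves unreadable from compound 2 to compound 3, that is, no change that could be told apart from repeated measurements. Compound 3 is thus estimated at 30000 nM, with a range from 5000 nM to 100000 nM, and with a real chance that the test again reports only a limit.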

Compound 3, concentration lethal to 50% of the cells: < 100000 nM
Compound 3 ended at the assay's limit; the forecaster's own chance of this, stated with the estimate: 65%; the middle value lies beyond the limit too.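

Among the compounds shown here, no step between compound 1, compound 2 and compound 3 can be read, in size or in direction, because all three results rest on a limit of the test: the limit of < 100000 nM in this assay, at which 3 of the 3 values shown sit.

The compounds shown leave open where each one actually lies in this assay, and so whether exchanging the group on this aromatic carbon changes anything.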